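Compound 1 to compound 3: one side group replaced

A few compounds are considered here, and "the series" means these few. Any claim that something is new, unique, unknown or untested is made for them only; others in the source may bear on it.

For the measured compounds named here, in a functional assay on MCF7 cells (Homo sapiens) for antiproliferative activity, read by MTT assay, with a stated time of 72 h (on this read-out higher numbers stand for weaker inhibition and lower numbers for stronger inhibition), compound 1 (`O=C1O[C@H]([C@@H](O)Cn2cc(CNS(=O)(=O)c3ccc(F)cc3)nn2)C(OCc2ccccc2)=C1OCc1ccccc1`) gives 26800 nM as the only true number so far. Compound 2 (`COc1ccccc1-c1cn(C/C=C2\OC(=O)C(OCc3ccccc3)=C2OCc2ccccc2)nn1`) stands at > 100000 nM as a limit of the assay, not a number. Compound 3 (`O=C1O[C@H]([C@@H](O)Cn2cc(CCCCl)nn2)C(OCc2ccccc2)=C1OCc1ccccc1`) keeps the core of compound 1 but carries 2-chloroethyl in place of ((4-fluorophenyl)sulfonyl)amino on a saturated chain carbon bound to an aromatic carbon. No measured step sizes this change, so in this assay the expected step of a 1.5-fold higher number from compound 1 to compound 3 (0.17 log units; within the scatter) is small, with no shift beyond the usual scatter. Compound 3 is expected at an estimated 40000 nM (range 12000 nM to 100000 nM).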

Compound 3, half-maximal inhibitory concentration: 24500 nM
Beside the measured number, compound 3's estimate is 1.6-fold (0.21 log units) above it; the range from low to high includes it.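

In this assay, swapping the side group gives a 1.1-fold lower number from compound 1 to compound 3 (0.04 log units; within the scatter). At this place, on a saturated chain carbon bound to an aromatic carbon, ((4-fluorophenyl)sulfonyl)amino with its aromatic ring and hydrogen-bond donor can therefore give way to 2-chloroethyl, which has neither, with no shift beyond the usual scatter. Nothing shown here explains why the two compounds read alike. Still open, going by these compounds, is whether an amine, a carboxylic acid or a longer chain at this place would move the number beyond the scatter.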